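A few compounds are considered here, and "the series" means these few. Any claim that something is new, unique, unknown or untested is made for them only; others in the source may bear on it.

Going by the values given here, the three compounds measured so far share one core and differ only in the group carried on the amide-type nitrogen. In a functional assay on CRL2813 cells (Homo sapiens) for cytotoxicity, read by sulforhodamine B assay, with a stated time of 5 days (on this read-out higher numbers stand for weaker inhibition and lower numbers for stronger inhibition), compound 1, `Cc1ccc(NC(=O)N[C@H]2CC[C@H](Oc3ccc(F)cc3)CC2)cc1`, gives > 20000 nM, which is a limit of the assay and not a number. Among the compounds with values here, compound 2, `COc1cccc(NC(=O)N[C@H]2CC[C@H](Oc3ccc(F)cc3)CC2)c1`, is the only one with an actual number: in this assay compound 2 gives 14000 nM. Within the data shown here, the one measured step between neighbours, an at least 1.4-fold lower number from compound 1 to compound 2 (0.15 log units; that floor lies within the scatter), cannot be separated from the usual scatter.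

Compound 3, `O=C(Nc1ccccc1OC(F)(F)F)N[C@H]1CC[C@H](Oc2ccc(F)cc2)CC1`, gives > 20000 nM in this assay, again a limit of the assay rather than a number. Compound 3 thus sits at the limit of > 20000 nM in this assay, at which 2 of the 3 values shown sit. Compound 4, `O=C(Nc1ccccc1Cl)N[C@H]1CC[C@H](Oc2ccc(F)cc2)CC1`, differs from compound 3 by chloro in place of trifluoromethoxy on an aromatic carbon. No measured step concerns this kind of change, and the only measured step stayed within the scatter, so nothing shown points to a large move in either direction. For compound 4 a step of an at least 1.1-fold lower number from compound 3 to compound 4 (0.04 log units; that floor lies within the scatter) is expected, which would not stand out from the scatter, and the result is most likely to be reported only as a limit. The estimate for compound 4 in this assay is 18000 nM, within a range from 6000 nM to 50000 nM.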

Compound 4, half-maximal inhibitory concentration: 9100 nM
Beside the measured number, compound 4's estimate is 2.0-fold (0.30 log units) above it, within the range that was stated.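

Going by these compounds alone, putting chloro in place of trifluoromethoxy on this aromatic carbon, ortho to a large group, gives the first step that clears the usual scatter: this assay shows an at least 2.1-fold lower number from compound 3 to compound 4 (0.34 log units; beyond the scatter), and as that step starts from a limit, its true size could be larger. The 2-chlorophenyl group also stands apart from the 4-methylphenyl group, with an at least 2.1-fold lower number from compound 1 to compound 4 (0.34 log units; beyond the scatter), but it cannot be separated from the 3-methoxyphenyl group, with a 1.5-fold lower number from compound 2 to compound 4 (0.19 log units; within the scatter), so the change helps against some of these groups and not against all of them. Only two compounds now give actual numbers, while the other two rest on a limit of the assay and not a number: the limit of > 20000 nM in this assay, at which 2 of the 4 values shown sit.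

Going by these compounds, it stays open whether fluoro, an amine or a carboxylic acid on this same aromatic carbon would lower the number further, and whether chloro would do the same on another carbon of the ring. On these data alone, the full size of the two steps that start from a limit also remains unknown.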